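The source may report more compounds than this note shows. Statements on the series, on what has been measured and on what is new or still open speak of the compounds shown alone.

Of the compounds shown here, three built on a shared core have been measured in a functional assay on HepG2 cells (Homo sapiens) for inhibition, read by MTT assay, with a stated time of 72 h; on this read-out lower numbers stand for stronger inhibition and higher numbers for weaker inhibition. Compound 1, with structure `CCCNC(=O)c1ccc(Oc2nc(-c3c(C)noc3C)cnc2N)cc1`, carries a propyl group on its amide nitrogen, and in this assay compound 1 gives 6880 nM. Compound 2, with structure `Cc1noc(C)c1-c1cnc(N)c(Oc2ccc(C(=O)Nc3ccccc3Cl)cc2)n1`, carries a 2-chlorophenyl group in that place. For compound 2 this assay reports only a limit, > 100000 nM. Compound 3, with structure `Cc1noc(C)c1-c1cnc(N)c(Oc2ccc(C(=O)Nc3cccc(Cl)c3)cc2)n1`, carries a 3-chlorophenyl group there, and compound 3 gives 7300 nM. The step of a 1.1-fold higher number from compound 1 to compound 3 (0.03 log units; within the scatter) is within the scatter, so compound 1 and compound 3 read alike, while the step of an at least 13-fold lower number from compound 2 to compound 3 (1.13 log units; beyond the scatter) is large, as is an at least 14-fold higher number from compound 1 to compound 2 (1.16 log units; beyond the scatter).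

Compound 4, with structure `Cc1noc(C)c1-c1cnc(N)c(Oc2ccc(C(=O)Nc3ccc(Cl)cn3)cc2)n1`, differs from compound 3 by 5-chloropyridin-2-yl in place of 3-chlorophenyl on an amide-type nitrogen. Within the data shown here, no measured step tests a ring nitrogen on this amide substituent. What the measured steps do show is that swapping groups on this amide nitrogen can leave the number unchanged, as from compound 1 to compound 3, or shift it strongly, as from compound 2 to compound 3. A modest step is expected for a 1.4-fold higher number from compound 3 to compound 4 (0.14 log units; within the scatter), and compound 4 is estimated at 10000 nM, within a range from 3000 nM to 40000 nM.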

Compound 4, half-maximal inhibitory concentration: 35600 nM
Beside the measured number, compound 4's estimate is 3.6-fold (0.55 log units) below it, and the stated range covers the measured number.
By their numbers in this assay, from the lowest: compounds 1 and 3 (each within the scatter of the next); then compound 4. At a limit, above all of these: compound 2.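

In this assay, among these compounds, the change from 3-chlorophenyl to 5-chloropyridin-2-yl on the amide-type nitrogen is the first measured step that brings a ring nitrogen into this substituent, and it lies beyond the scatter: a 4.9-fold higher number from compound 3 to compound 4 (0.69 log units; beyond the scatter). The step from the propyl group to the same pyridine ring is of similar size, a 5.2-fold higher number from compound 1 to compound 4 (0.71 log units; beyond the scatter), so compound 4 reads apart from compounds 1 and 3, which read alike, and the position now shows an intermediate level of the number rather than only two. The step of an at least 2.8-fold lower number from compound 2 to compound 4 (0.44 log units; beyond the scatter) starts from a limit and not from a true number, so it gives only a bound on how far compound 4 lies from compound 2: the limit of > 100000 nM in this assay, at which 1 of the 4 values shown sits.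

On these data alone, whether the higher number of compound 4 comes from the ring nitrogen itself or from how the chlorine is placed on the ring stays open, and telling these apart would take a comparison with a pyridin-2-yl group without chlorine or with a 4-chlorophenyl group. As far as these compounds go, the reason for the shift also stays open, as does how a piperidine or a longer alkyl chain on this nitrogen would read.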